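The source may hold more compounds than are shown below. What is called first, only, known or untested is meant among the compounds shown, and "the series" means these compounds.

Measured so far:
- compound 1 `COc1ccc(C[C@H]2C(=O)OC[C@@H]2Cc2ccccc2)cc1` gives 67000 nM in a functional assay on HL-60 cells (Homo sapiens) for cytotoxicity, read by WST assay, with a stated time of 48 h; a higher number here means that more compound is needed for the effect, a lower number that less compound is needed
- compound 2 `CCCCOc1ccc(C[C@H]2C(=O)OC[C@@H]2Cc2ccccc2)cc1` gives 23000 nM in this assay

Compound 2 has the lower of these two numbers. Compound 3 `O=C1OC[C@H](Cc2ccccc2)[C@H]1Cc1ccc(F)cc1` has fluoro in place of butoxy on an aromatic carbon and awaits measurement. Going by the values given here, one measured step bears on this change, the modest 2.9-fold lower number from compound 1 to compound 2 (0.46 log units; beyond the scatter) that lies beyond the scatter. Among the compounds with values here, no fluoro compound has been measured yet, so a modest to moderate step toward a higher number is expected in this assay and is estimated as a 2.4-fold higher number from compound 2 to compound 3 (0.38 log units; beyond the scatter) in size. Compound 3 is expected at 55000 nM within an estimated range of 22000 nM to 130000 nM overall.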

Compound 3, half-maximal effective concentration: 57000 nM
For compound 3 the middle estimate is 1.0-fold (0.02 log units) below the measured one; the range from low to high includes it.
By their numbers in this assay, from the lowest: compound 2; then compounds 3 and 1 (each within the scatter of the next).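

In this assay fluoro in place of butoxy on this aromatic carbon gives a 2.5-fold higher number from compound 2 to compound 3 (0.39 log units; beyond the scatter) and so gives up the gain seen with the longer chain, while fluoro in place of methoxy gives a 1.2-fold lower number from compound 1 to compound 3 (0.07 log units; within the scatter) and leaves the two groups indistinguishable here. Of the three groups at this carbon, only butoxy stands apart from the other two. No evidence is at hand to explain this.

The compounds shown leave open whether a hexyloxy chain would lower the number further. They also leave open how an amine or a carboxylic acid at this carbon would compare.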